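Swapping methoxy for trifluoromethyl on a urea anilide

A few compounds are considered here, and "the series" means these few. Any claim that something is new, unique, unknown or untested is made for them only; others in the source may bear on it.

Of the compounds shown here, three sharing one core have been measured in a functional assay on NCI-H1581 cells (Homo sapiens) for inhibition, read by MTT assay, with a stated time of 48 h, tested at 10 uM; on this read-out higher numbers stand for more inhibition at the one concentration tested (going by the name of the read-out) and lower numbers for less inhibition. Compound 1, `Cc1ccc(Nc2cc(NC(=O)Nc3c(Cl)cccc3Cl)ncn2)cc1F`, gives 45.3%. Compound 2, `COc1cc(NC(=O)Nc2cc(Nc3cccc(C(C)(C)C)c3)ncn2)cc(OC)c1`, gives 35.1% in this assay. Compound 3, `COc1cc(Nc2cc(NC(=O)Nc3c(Cl)cccc3Cl)ncn2)cc(OC)c1`, gives 68% in this assay and stands highest of the three numbers, its gap to compound 1 and its larger gap to compound 2 both lying beyond the scatter. Among the compounds with values here, no single-point step between two measured compounds is available, so the effect of the change now considered cannot be read from a neighbouring pair.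

Compound 4, `COc1cc(Nc2cc(NC(=O)Nc3c(Cl)cccc3Cl)ncn2)cc(C(F)(F)F)c1`, differs from compound 3 in one place: trifluoromethyl in place of methoxy on an aromatic carbon. Within the data shown here, with no measured pair to lean on, a modest fall in this assay is expected, of a size that may or may not exceed the scatter, and the expected step is a number 13 percentage points lower from compound 3 to compound 4 (beyond the scatter). Compound 4 is therefore estimated to give 55% in this assay, within a range from 35% to 75%.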

Compound 4, a percentage reported as inhibition, at one concentration (the size of the read-out at that concentration, not a potency): 32.3%
Beside the measured number, compound 4's estimate is 22.7 percentage points above it; the whole stated range lies above it.
By their numbers in this assay, from the lowest: compounds 4 and 2 (each within the scatter of the next); then compound 1; then compound 3.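

Read in this assay, this exchange gives the first direct measure of a change at this position: the step is a number 35.7 percentage points lower from compound 3 to compound 4 (beyond the scatter), so the number is lower with trifluoromethyl than with methoxy on this aromatic carbon, meta to a large group. The second methoxy and the rest of the molecule stay the same, so the whole step belongs to trifluoromethyl in place of methoxy at this one place. No measurement of any property of these compounds is available that would account for the size of this step.

This single exchange does not separate the loss of methoxy from the arrival of trifluoromethyl. On these data alone, how a hydroxyl, an amine or an ethoxy group on this same carbon would read out remains open, as does whether the step would recur on another part of the shared core.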